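The source may hold more compounds than are shown below. What is called first, only, known or untested is meant among the compounds shown, and "the series" means these compounds.

Two compounds share one core and differ only in the chain that hangs from the sulfur. Compound 1 `O=C(O)Cn1c(SCCOc2cccc3ccccc23)nc2ccccc21` carries a naphthyloxy group on that chain, and in an assay on HEK293 cells for displacement of a labelled ligand from prostaglandin D2 receptor 2 (Homo sapiens) (on this read-out higher numbers stand for weaker inhibition and lower numbers for stronger inhibition), compound 1 gives 2000 nM. Compound 2 `O=C(O)Cn1c(SCCCNc2ccccc2)nc2ccccc21` carries an anilino group instead, and in this assay compound 2 gives 2690 nM. Compound 2 holds the highest of the two numbers, yet its nearest neighbour, compound 1, lies within the scatter of it, so the two cannot be told apart on these numbers.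

Compound 3 `CCCCCSc1nc2ccccc2n1CC(=O)O` takes the step away from an aromatic ring on the chain altogether: ethyl in place of anilino on a saturated chain carbon, three bonds along the chain from a sulfur. Within the data shown here, no measured pair in this set shows a step of this kind, so the expectation rests only on the fact that both measured compounds keep an aromatic ring out on the chain and that neither reaches a strong number. A step towards a weaker number, beyond the scatter, is expected from compound 2 to compound 3 in this assay, of about a 3.0-fold higher number from compound 2 to compound 3 (0.47 log units; beyond the scatter). Compound 3 is therefore estimated at 8000 nM, with a range from 2500 nM to 25000 nM.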

Compound 3, half-maximal inhibitory concentration: 1240 nM
Estimate against measurement, compound 3: 6.5-fold (0.81 log units) above; the whole stated range lies above it.
By their numbers in this assay, from the lowest: compounds 3, 1 and 2 (each within the scatter of the next, the first and the last beyond it).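

In this assay, ethyl in place of anilino on a saturated chain carbon, three bonds along the chain from a sulfur, gives a 2.2-fold lower number from compound 2 to compound 3 (0.34 log units; beyond the scatter), which on this read-out means modestly stronger inhibition. The earlier pair could not show this: both of its compounds keep an aromatic ring out on the chain, whereas compound 3 shows that at this place a plain saturated chain, with no ring and no hydrogen-bond donor or acceptor in the entering group, holds its own and even improves slightly on the anilino group. Nothing available here explains what lies behind this step.

The change removes the ring and the nitrogen together, so the compounds shown leave open which of the two matters; a phenyl group at the same place, which keeps the ring without the amine, would separate them. Also open, from the compounds shown here alone, is how the number responds to the size of a plain group here, for example a methyl group or a butyl group in place of the ethyl.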